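A few compounds are considered here, and "the series" means these few. Any claim that something is new, unique, unknown or untested is made for them only; others in the source may bear on it.

Measured in a functional assay on thoracic aorta (Rattus norvegicus, strain Wistar), with a stated time of 15 min; a higher number here means that more compound is needed for the effect, a lower number that less compound is needed:
- compound 1 `Cc1ccc(S(=O)(=O)NC(=O)NC(C)c2ccccc2OCc2ccccc2)cc1`: > 200000 nM
- compound 2 `Cc1ccc(S(=O)(=O)N(C)C(=O)NC(C)c2cc(C)ccc2OCc2ccccc2)cc1`: 181000 nM

Among the compounds with values here, compound 2 holds the only actual number in this assay. The value of compound 1 is a limit, not a number. Compound 3 `Cc1ccc(S(=O)(=O)NC(=O)NC(C)c2cc(C)ccc2OCc2ccccc2)cc1` differs from compound 2 by hydrogen in place of methyl on an amide-type nitrogen. Compound 1 also carries that hydrogen, and its limit of > 200000 nM gives no hint of a large gain. The expected step, a 1.1-fold lower number from compound 2 to compound 3 (0.05 log units; within the scatter), stays within the scatter. For compound 3, the estimated value is 160000 nM, with an expected range of 60000 nM to 350000 nM.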

Compound 3, half-maximal effective concentration: 91900 nM
Beside the measured number, compound 3's estimate is 1.7-fold (0.24 log units) above it; measured number inside the range.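

In this assay, hydrogen in place of methyl on the amide-type nitrogen gives a 2.0-fold lower number from compound 2 to compound 3 (0.29 log units; within the scatter), so this change shows no step beyond the scatter. Methyl in place of hydrogen on an aromatic carbon gives an at least 2.1-fold lower number from compound 1 to compound 3 (0.33 log units; beyond the scatter), the only step in the series printed as beyond the scatter. The value of compound 1 is a limit, so the full size of that step stays unknown: the limit of > 200000 nM in this assay, at which 1 of the 3 values shown sits.

Still open, as far as these compounds go, is whether an amine or a carboxylic acid on that aromatic carbon, or a longer chain on the amide-type nitrogen, would shift the number further.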